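Adding methoxy to the aromatic ring of compound 1

The compounds below may be only part of what the source reports. "The series", "measured", "known", "first", "only" and "open" are said of these compounds alone.

Within the data shown here, in a functional assay on NCI/ADR-RES cells (Homo sapiens) for inhibition, read by sulforhodamine B assay, with a stated time of 48 h (a lower number here means a stronger inhibitor of growth, a higher number a weaker inhibitor of growth), compound 1 (`CC1(/C=C/c2ccccc2)C=CC(=O)O1`) gives 414000 nM, the highest of the three numbers so far. Compound 3 (`CC1(/C=C/c2ccc(O)cc2)C=CC(=O)O1`) gives 111000 nM, and compound 2 (`CC1(/C=C/c2ccc(C(F)(F)F)cc2)C=CC(=O)O1`) gives 9400 nM. Compound 4 (`COc1ccccc1/C=C/C1(C)C=CC(=O)O1`) has not been measured and carries methoxy in place of hydrogen on an aromatic carbon.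

Two measured replacements of an aromatic hydrogen bear on this change, and both lowered the number. Trifluoromethyl gave a large step, a 44-fold lower number from compound 1 to compound 2 (1.64 log units; beyond the scatter), and hydroxy gave a modest one, a 3.7-fold lower number from compound 1 to compound 3 (0.57 log units; beyond the scatter). Among the measured compounds shown here, no measured compound carries methoxy. Hydroxy is the closer comparison, as oxygen is attached to the ring in both compound 3 and compound 4, so the step to compound 3, a 3.7-fold lower number from compound 1 to compound 3 (0.57 log units; beyond the scatter), serves as the guide. A modest lowering is therefore expected, with a real chance of no step beyond the scatter: a 3.5-fold lower number from compound 1 to compound 4 (0.54 log units; beyond the scatter) is the expected step. For compound 4 the estimated value is 120000 nM, with an expected range of 30000 nM to 400000 nM.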

Compound 4, concentration for total growth inhibition: 64500 nM
The estimate for compound 4 lay 1.9-fold (0.27 log units) above the measured number; measured number inside the range.
By their numbers in this assay, from the lowest: compound 2; then compounds 4 and 3 (each within the scatter of the next); then compound 1.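

In this assay, methoxy on the aromatic carbon ortho to the group of 9 heavy atoms goes with a 6.4-fold lower number from compound 1 to compound 4 (0.81 log units; beyond the scatter), so a replacement of hydrogen at this ring carbon also lowers the number. Compounds 2 and 3 carry their groups at another ring carbon, so compound 4 extends the series to a new place on the ring, and all three replacements shown now lower the number from that of compound 1. No measurement shown bears on the cause of this step.

Open, from the compounds shown here alone, is how methoxy at another ring carbon would behave, and whether hydroxy or trifluoromethyl ortho to the group of 9 heavy atoms would give steps of similar size. Also open, going by these compounds, is the effect of an amine, a carboxylic acid or a longer chain such as ethoxy at this carbon.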